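The source may hold more compounds than are shown below. What is called first, only, known or untested is meant among the compounds shown, and "the series" means these compounds.

Measured so far:
- compound 2 `O=C(/C=C/c1coc2cc(O)ccc2c1=O)NCc1ccccc1` — in a functional assay on Huh-7 cells (Homo sapiens) for inhibition, read by MTT assay, with a stated time of 48 h (a lower number here means a stronger inhibitor, a higher number a weaker inhibitor), compound 2 gives 4690 nM
- compound 1 `COc1ccc(CNC(=O)/C=C/c2coc3cc(O)ccc3c2=O)cc1` — in this assay compound 1 gives 8430 nM

Within the data shown here, compound 2 is one of only two measured points; the single known step, a 1.8-fold lower number from compound 1 to compound 2 (0.25 log units; within the scatter), separates the two and is within the scatter, so neither number can be set above or below the other.

Compound 3 `O=C(/C=C/c1coc2cc(O)ccc2c1=O)Nc1ccccc1` is next. The change is phenyl in place of benzyl on an amide-type nitrogen. Among the measured compounds shown here, no measured step touches this position: the one step on record, a 1.8-fold lower number from compound 1 to compound 2 (0.25 log units; within the scatter), concerns a substituent on the aromatic ring of the amide side chain, not the link between that ring and the amide nitrogen. There is therefore no measured ground for expecting a step beyond the scatter in this assay in either direction, and the default expectation is a number close to that of compound 2.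

For the measured compounds named here, on that basis compound 3 is estimated at 4700 nM in this assay, with a range of 1500 nM to 15000 nM, the expected step being a 1.0-fold higher number from compound 2 to compound 3 (0.00 log units; within the scatter), and the range is set wide because no prior step informs this change.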

Compound 3, half-maximal inhibitory concentration: 3880 nM
The estimate for compound 3 lay 1.2-fold (0.08 log units) above the measured number; low and high end bracket the measured number.
By their numbers in this assay, from the lowest: compounds 3, 2 and 1 (each within the scatter of the next, the first and the last beyond it).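

In this assay, the change from benzyl to phenyl on the amide-type nitrogen gives a 1.2-fold lower number from compound 2 to compound 3 (0.08 log units; within the scatter) and so does not separate the two compounds. Among these compounds, this is the first reading on how the aromatic ring is attached to the amide nitrogen, as the earlier step, a 1.8-fold lower number from compound 1 to compound 2 (0.25 log units; within the scatter), concerned only a methoxy substituent on that ring; benzylamino and anilino cannot be told apart at this level of resolution, and with the aromatic ring kept, this attachment has not yet produced a step beyond the scatter. No measurement at hand bears on the reason for this result.

Still open, as far as these compounds go, is whether a longer chain, such as phenylethyl or phenylpropyl, on the amide-type nitrogen would give a step beyond the scatter, and whether the aromatic ring is needed at all, which cyclohexyl or a plain methyl in its place would test. Also open, from the compounds shown here alone, is how a dimethylamino group or a carboxylic acid on the aromatic ring of the anilino amide would read in this assay as a step from compound 3.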